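This account rests on a few compounds, and the source may have more. Where it says the series, first, only, none or still open, it means among the compounds named here.

Working notes on the series. Compound 1 `CC1=C(SCCC(=O)OC(C[Se]c2ccccc2)C(=O)NCCCCCC(=O)OCc2ccccc2)C(=O)c2ccccc2C1=O` is the parent member. In a functional assay on A498 cells (Homo sapiens) for cytotoxicity, read by MTT assay, with a stated time of 24 h (a lower number here means a stronger inhibitor, a higher number a weaker inhibitor), compound 1 gives > 100000 nM, which is a limit of the assay and not a number. Compound 2 `CC1=C(SCCC(=O)OC(C[Se]C2=C(C)C(=O)c3ccccc3C2=O)C(=O)NCCCCCC(=O)OCc2ccccc2)C(=O)c2ccccc2C1=O` carries a second copy of the shared core in place of the side group of compound 1, and in this assay compound 2 gives 5000 nM. Among the compounds with values here, no step between these two is worked out, so only the two values themselves can be set side by side. Compound 1 sits at the limit of > 100000 nM in this assay, at which 1 of the 2 values shown sits, the weak end of what has been measured so far.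

Compound 3 `CC1=C(SCCC(=O)OC(CC[Se]c2ccccc2)C(=O)NCCCCCC(=O)OCc2ccccc2)C(=O)c2ccccc2C1=O` is not yet measured. It differs from compound 1 by a group of 8 heavy atoms (7 carbon, 1 selenium; one six-membered aromatic ring of carbon only) in place of a group of 7 heavy atoms (6 carbon, 1 selenium; one six-membered aromatic ring of carbon only), on a saturated chain carbon, two bonds along the chain from a carbonyl carbon and an oxygen next to a carbonyl group, that is, the chain to the ring-bearing selenium is one saturated carbon longer. With compound 1 known only as a limit, a change of this size gives no ground to expect a shift beyond the scatter. The step that the limit leaves unreadable from compound 1 to compound 3 is accordingly expected to be about nil. Compound 3 is expected to give 150000 nM in this assay, with a range from 40000 nM to 600000 nM, and most likely the assay will again report only a limit.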

Compound 3, half-maximal inhibitory concentration: > 100000 nM
Compound 3 gave a limit, no number; the forecaster's own chance of this, stated with the estimate: 65%; the middle value lies beyond the limit too.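

In this assay, within the data shown here, compound 1 and compound 3 each give only a limit of the assay and not a number, so no step between them can be read. The compounds shown leave open whether a chain to the ring-bearing selenium that is one saturated carbon longer changes the value at all, since neither compound gives a number to compare.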